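Working notes: cytotoxicity of the methyl and ethyl analogues

The source may hold more compounds than are shown below. What is called first, only, known or untested is meant among the compounds shown, and "the series" means these compounds.

Measured compounds:
compound 1 `O=C1Nc2ccccc2/C1=N/NC(=S)Nc1ccccc1`, in an ADME assay on RD cells (Homo sapiens) for cytotoxicity (on this read-out lower numbers stand for higher toxicity in this test and higher numbers for lower toxicity in this test), compound 1 gives > 25000 nM.
compound 2 `CNC(=S)N/N=C1\C(=O)Nc2ccccc21`, in this assay compound 2 gives > 25000 nM.

The value of compound 1 in this assay is a limit of the assay and not a number. The value of compound 2 in this assay is likewise a limit. The step that the two limits leave unreadable from compound 1 to compound 2 is therefore not readable from the two values. Where compound 2 stands is known only as a limit, as the limit of > 25000 nM in this assay, at which 2 of the 2 values shown sit, shows, so no position on a scale of numbers can be given for it.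

Compound 3 `CCNC(=S)N/N=C1\C(=O)Nc2ccccc21` differs from compound 2 by methyl in place of hydrogen on a saturated chain carbon bound to an amide-type nitrogen. Going by the values given here, no measured step is readable, so none bears on the size of this change, and no direction can be drawn from the data. The step that the limit leaves unreadable from compound 2 to compound 3 is expected to be none beyond the scatter. Compound 3 is therefore estimated at 40000 nM, with a range from 15000 nM to 120000 nM, and most likely the assay will again report only a limit.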

Compound 3, half-maximal cytotoxic concentration: > 25000 nM
Compound 3 ended at the assay's limit; the forecaster's own chance of this, stated with the estimate: 80%; the middle value is on the limit's open side.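

In this assay, going by these compounds alone, compound 3 gives > 25000 nM, a limit and not a number, so no step among compound 1, compound 2 and compound 3 can be read. The series shares a single reading: the limit of > 25000 nM in this assay, at which 3 of the 3 values shown sit. The compounds shown leave open where any of the three lies on a scale of numbers, and whether these changes have any effect on the read-out.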